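The compounds below may be only part of what the source reports. "The series", "measured", "known", "first", "only" and "open" are said of these compounds alone.

Within the data shown here, compound 1 `O=C(NCCCCl)Nc1ccc(I)cc1` is one of three compounds measured in a functional assay on M21 cells (Homo sapiens) for antiproliferative activity, with a stated time of 48 h; a lower number here means a stronger inhibitor, a higher number a weaker inhibitor. In this assay compound 1 gives > 100000 nM, which is a limit of the assay and not a number. Compound 2 `CC(C)(C)c1ccc(NC(=O)NCCCCl)cc1` gives 35000 nM in this assay. Compound 3 `CCCCC(OC)c1cccc(NC(=O)NCCCCl)c1` gives 51000 nM in this assay. Compound 1 thus stands at the weak end of the measured compounds, at the limit of > 100000 nM in this assay, at which 1 of the 3 values shown sits. Among the measured compounds shown here, the only step that can be counted is an at least 2.8-fold lower number from compound 1 to compound 2 (0.45 log units; beyond the scatter); it changes the substituent on the aromatic ring and leaves the urea side untouched.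

Compound 4 `O=C(CCl)Nc1ccc(I)cc1` has not been measured. It differs from compound 1 by chloromethyl in place of (3-chloropropyl)amino on a carbonyl carbon. For the measured compounds named here, no measured step alters this part of the shared core, so the step from compound 1 to compound 2 does not bear directly on the change to compound 4; it shows only that a single change can move the number beyond the scatter. Because compound 1 sits at the limit of > 100000 nM in this assay, at which 1 of the 3 values shown sits, any expectation for compound 4 is loosely anchored, and a number in the same weak region or again a limit both seem plausible. Compound 4 is expected to give 50000 nM in this assay. For compound 4 the expected range runs from 10000 nM to 150000 nM. This amounts to an expected step of an at least 2.0-fold lower number from compound 1 to compound 4 (0.30 log units; that floor lies within the scatter).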

Compound 4, half-maximal inhibitory concentration: 5100 nM
Beside the measured number, compound 4's estimate is 9.8-fold (0.99 log units) above it, outside the stated range (below it).
By their numbers in this assay, from the lowest: compound 4; then compounds 2 and 3 (each within the scatter of the next). At a limit, above all of these: compound 1.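

In this assay, the result shows that the carbonyl carbon whose other neighbour is the amide-type nitrogen is a place where a single change can move the number: an at least 19-fold lower number from compound 1 to compound 4 (1.29 log units; beyond the scatter). The earlier step touched only the substituent on the aromatic ring, whereas this one keeps the iodo group and replaces (3-chloropropyl)amino with chloromethyl, so the urea side, left untouched until now, also proves to matter in this assay. The size of the step is only a floor, because compound 1 stands at a limit and not at a number: the limit of > 100000 nM in this assay, at which 1 of the 4 values shown sits.

The change removes the nitrogen with its hydrogen-bond donor and shortens the chain in one move, so the compounds shown do not tell which of these goes with the lower number, or whether the chlorine in chloromethyl plays any part. Also open, from the compounds shown here alone, are how a plain methyl group or a longer chloroalkyl chain on the same carbonyl carbon would read, and whether tert-butyl in place of iodo would shift the number in the same direction when chloromethyl is present.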